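The compounds below may be only part of what the source reports. "The series", "measured", "known", "first", "only" and "open" are said of these compounds alone.

Compound 1 `CC1=C(C(=O)OCC(C)C)C(c2ccco2)NC(=S)N1` in an assay on membranes from HEK293 cells for displacement of a labelled ligand from adenosine receptor A2b (Homo sapiens), read by scintillation counting, with a stated time of 30 min, tested at 1 uM (on this read-out lower numbers stand for less inhibition and higher numbers for more inhibition at the one concentration tested (going by the name of the read-out)), gives 18%.
Compound 2 `COC(=O)C1=C(C)NC(=S)NC1c1ccoc1` gives 48%.
Compound 3 `CCCOC(=O)C1=C(C)NC(=S)NC1c1ccoc1` gives 45%.

Among these three numbers compound 3 stands second highest. Its nearest neighbour is compound 2, within the usual scatter, while compound 1 lies much lower, beyond the scatter. Compound 4 `CC1=C(C(=O)OCC(C)C)C(c2ccoc2)NC(=S)N1` differs from compound 3 in one place: methyl in place of hydrogen on a saturated chain carbon bound to two saturated chain carbons. Among the compounds with values here, the one measured step that touches the same chain, the one bound to the oxygen next to the carbonyl group, is a number 3 percentage points lower from compound 2 to compound 3 (within the scatter), and it stayed within the scatter. On that basis no shift beyond the scatter is expected, which the estimated step of a number 3 percentage points lower from compound 3 to compound 4 (within the scatter) expresses. Compound 4 is therefore expected to give 42% in this assay, within a range from 22% to 58%.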

Compound 4, a percentage reported as inhibition, at one concentration (the size of the read-out at that concentration, not a potency): 1%
Beside the measured number, compound 4's estimate is 41 percentage points above it, outside the stated range (below it).
By their numbers in this assay, from the lowest: compound 4; then compound 1; then compounds 3 and 2 (each within the scatter of the next).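

On the chain bound to the oxygen next to the carbonyl group, one added methyl matters far more than the earlier ethyl did in this assay: turning propoxy into isobutoxy gives a large drop (a number 44 percentage points lower from compound 3 to compound 4 (beyond the scatter)), and the isopropyl change gives a similar one (a number 47 percentage points lower from compound 2 to compound 4 (beyond the scatter)). With the isobutoxy chain kept, the furan attachment also counts, with furan-3-yl in place of furan-2-yl giving a modest drop (a number 17 percentage points lower from compound 1 to compound 4 (beyond the scatter)). No evidence here bears on why one methyl has so large an effect. Going by these compounds, whether an unbranched butoxy chain would behave like propoxy or like isobutoxy remains open. So does the effect of an amine at the end of this chain.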